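Tetrazole Substituent Swap on a Second Thiazolylidene Core

This account rests on a few compounds, and the source may have more. Where it says the series, first, only, none or still open, it means among the compounds named here.

Compound 1 `Cc1ccc(-c2cs/c(=N/NC(=O)CSc3nnnn3-c3ccccc3)n2-c2ccccc2)cc1` gives 14.7 ug/mL in a functional assay on C6 cells (Rattus norvegicus) for cytotoxicity, read by MTT assay, with a stated time of 24 h; on this read-out higher numbers stand for weaker inhibition and lower numbers for stronger inhibition.
Compound 2 `Cc1ccc(-c2cs/c(=N/NC(=O)CSc3nnnn3C)n2-c2ccccc2)cc1` gives 36.3 ug/mL in this assay.
Compound 3 `O=C(CSc1nnnn1-c1ccccc1)N/N=c1/scc(-c2ccccc2)n1-c1ccccc1` gives 8.3 ug/mL in this assay.

Of the compounds shown here, three have been measured. Compound 1 and compound 2 share a core and differ by methyl in place of phenyl on an aromatic nitrogen; that change produces a 2.5-fold higher number from compound 1 to compound 2 (0.39 log units; beyond the scatter). Compound 3 differs from compound 1 by hydrogen in place of methyl on an aromatic carbon, and the step between them is a 1.8-fold lower number from compound 1 to compound 3 (0.25 log units; within the scatter), so compound 1 and compound 3 cannot be ordered against each other on these numbers. Compound 3 does stand apart from compound 2, whose number is higher by a margin beyond the scatter.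

Compound 4 `Cn1nnnc1SCC(=O)N/N=c1/scc(-c2ccccc2)n1-c1ccccc1` has not yet been measured in this assay. It stands to compound 3 exactly as compound 2 stands to compound 1: the difference is methyl in place of phenyl on an aromatic nitrogen, and the place of the change is described in the same words for both pairs, so this is the same change made on the core of compound 3 rather than on the core of compound 1. Because that change gave a 2.5-fold higher number from compound 1 to compound 2 (0.39 log units; beyond the scatter) when it was made once, compound 4 is expected to move by a step of about a 2.5-fold higher number from compound 3 to compound 4 (0.40 log units; beyond the scatter) from compound 3, though a single earlier occurrence is a thin basis. Compound 4 is therefore estimated at 21 ug/mL, with a plausible range from 12 ug/mL to 38 ug/mL.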

Compound 4, half-maximal inhibitory concentration: 67.7 ug/mL
Beside the measured number, compound 4's estimate is 3.2-fold (0.51 log units) below it; the measured number lies above the stated range.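

In this assay, the exchange of 1-phenyl-1H-tetrazol-5-yl for 1-methyl-1H-tetrazol-5-yl on the core of compound 3 gives an 8.2-fold higher number from compound 3 to compound 4 (0.91 log units; beyond the scatter), a step in the same direction as on the core of compound 1 but of a size that did not carry over: the same change on two cores in this assay, a 2.5-fold higher number (0.39 log units; beyond the scatter) from compound 1 to compound 2 and an 8.2-fold higher number (0.91 log units; beyond the scatter) from compound 3 to compound 4, 3.3-fold (0.52 log units) apart, beyond the scatter of two such steps.
Seen along the other edge of the same four compounds, hydrogen in place of methyl on an aromatic carbon gives a 1.9-fold higher number from compound 2 to compound 4 (0.27 log units; within the scatter), so compound 2 and compound 4 cannot be ordered against each other, and this step still sits apart from its earlier counterpart: the same change on two cores in this assay, a 1.8-fold lower number (0.25 log units; within the scatter) from compound 1 to compound 3 and a 1.9-fold higher number (0.27 log units; within the scatter) from compound 2 to compound 4, 3.3-fold (0.52 log units) apart, beyond the scatter of two such steps.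
These four compounds thus show that the direction of the tetrazole change held on both cores and that its size depended on the core, but with a single pair of cores they give neither a size to expect on a further core nor any reason for the gap.

The compounds shown leave open whether the gap would persist with chlorine or a methoxy group in place of that methyl on the aromatic carbon. They also leave open where an ethyl or a benzyl group on the tetrazole nitrogen would fall relative to methyl and phenyl on either core.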